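The source may hold more compounds than are shown below. What is called first, only, known or untested is meant among the compounds shown, and "the series" means these compounds.

Measured in a functional assay on MCF7 cells (Homo sapiens) for inhibition, read by MTT assay, with a stated time of 72 h; on this read-out higher numbers stand for weaker inhibition and lower numbers for stronger inhibition:
- Compound 1 `C[C@H](NC(=O)c1cc(Cl)ccc1OCCNC(=O)OC(C)(C)C)C(=O)Nc1ccc([N+](=O)[O-])cc1Cl`: > 10000 nM, a limit and not a number.
- Compound 2 `CC(C)[C@H](NC(=O)c1cc(Cl)ccc1OCCNC(=O)OC(C)(C)C)C(=O)Nc1cc(F)cc(C(F)(F)F)c1`: 11500 nM.
- Compound 3 `CC(C)[C@H](NC(=O)c1cc(Cl)ccc1OCCN)C(=O)Nc1cc(F)cc(C(F)(F)F)c1`: > 10000 nM, a limit and not a number.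

Compound 3 has no exact value and sits at the limit of > 10000 nM in this assay, at which 2 of the 3 values shown sit. Compound 4 `CC(C)[C@H](NC(=O)c1cc(Cl)ccc1OCCN)C(=O)Nc1cc(C(F)(F)F)cc(C(F)(F)F)c1` differs from it by one group, with trifluoromethyl in place of fluoro on an aromatic carbon. For the measured compounds named here, the only measured step is a step that the limit leaves unreadable from compound 2 to compound 3, and it is a different change, at an amine nitrogen, so it gives no size to carry over. Going by the values given here, the one exact value belongs to compound 2, at 11500 nM. In this assay, no step beyond the usual scatter is therefore expected, and the estimated step is an at least 1.1-fold lower number from compound 3 to compound 4 (0.04 log units; that floor lies within the scatter). The estimate for compound 4 is 9000 nM, with an expected range of 3000 nM to 25000 nM.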

Compound 4, half-maximal inhibitory concentration: 6010 nM
For compound 4 the middle estimate is 1.5-fold (0.18 log units) above the measured one; low and high end bracket the measured number.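

In this assay, trifluoromethyl in place of fluoro on an aromatic carbon gives an at least 1.6-fold lower number from compound 3 to compound 4 (0.22 log units; that floor lies within the scatter). With this change, compound 4 becomes the only compound shown carrying the free amine that has an exact value. The full size of the step remains unknown because compound 3 sits at a limit: the limit of > 10000 nM in this assay, at which 2 of the 4 values shown sit.

The compounds shown leave open whether a nitrile or a methoxy group at this place would give a similar value. They also leave open how a longer chain on the amine would affect the value.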